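The source may hold more compounds than are shown below. What is called first, only, known or untested is meant among the compounds shown, and "the series" means these compounds.

Measured so far in a functional assay on HEK293 cells with D(4) dopamine receptor (Homo sapiens) as the target, read by FLIPR; on this read-out lower numbers stand for an effect already at smaller amounts and higher numbers for an effect only at larger amounts of compound:
compound 1 `O/N=C(\CCN1CCN(c2ccccn2)CC1)c1ccccc1Cl` gives 24 nM
compound 2 `CO/N=C(\CCN1CCN(c2ccccn2)CC1)c1ccccc1Cl` gives 42.3 nM
compound 3 `O/N=C(\CCCN1CCN(c2ccccn2)CC1)c1ccc(F)cc1` gives 9.5 nM

Compound 4 `CO/N=C(\CCCN1CCN(c2ccccn2)CC1)c1ccc(F)cc1` is not yet measured in this assay. The change from compound 3 to compound 4 is methyl in place of hydrogen on an oxygen. The same change has been made once before, from compound 1 to compound 2: methyl in place of hydrogen on an oxygen, and there it gave a 1.8-fold higher number from compound 1 to compound 2 (0.25 log units; within the scatter). For the measured compounds named here, the difference between the core of compound 1 and the core of compound 3 is not broken down here, so the earlier step is the only guide for the new one. Compound 4 is expected to stay close to compound 3 in this assay, with a step of about a 1.8-fold higher number from compound 3 to compound 4 (0.25 log units; within the scatter), because a 1.8-fold higher number from compound 1 to compound 2 (0.25 log units; within the scatter) stayed within the scatter. For compound 4 the estimate is 17 nM, with the likely range from 8 nM to 40 nM.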

Compound 4, half-maximal effective concentration: 41.7 nM
For compound 4 the middle estimate is 2.5-fold (0.39 log units) below the measured one, and the stated range ends below it.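

In this assay, methyl in place of hydrogen on the oxygen gives a 4.4-fold higher number from compound 3 to compound 4 (0.64 log units; beyond the scatter). Set beside the step on the other core, the gap stays within what two such steps can scatter: the same change on two cores in this assay, a 1.8-fold higher number (0.25 log units; within the scatter) from compound 1 to compound 2 and a 4.4-fold higher number (0.64 log units; beyond the scatter) from compound 3 to compound 4, 2.5-fold (0.40 log units) apart, within the scatter of two such steps. The two cores are therefore compatible with one shared step for hydroxy to methoxy, and the number rises on both, but two pairs cannot show that the size of the step is fixed, nor that it is independent of the core.

On these data alone, an ethyl or a benzyl on that oxygen remains open. So does the step on a core that differs from these two in one place only, which would show whether any single part of the core alters it.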